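Methyl in place of acetyl on an amine nitrogen

A few compounds are considered here, and "the series" means these few. Any claim that something is new, unique, unknown or untested is made for them only; others in the source may bear on it.

In a functional assay (on this read-out higher numbers stand for weaker inhibition and lower numbers for stronger inhibition), compound 1 (`CC(=O)N1CCC2(CC1)CC(=O)c1cc3c(cc1O2)CCC(C)(C)O3`) gives 5320 nM and compound 2 (`CC(=O)N1CCC2(CC1)CC(=O)c1c(ccc3c1CCC(C)(C)O3)O2`) gives 6590 nM so that the two stand within the scatter of each other. Compound 3 (`CN1CCC2(CC1)CC(=O)c1c(ccc3c1CCC(C)(C)O3)O2`) carries methyl in place of acetyl on an amine nitrogen in a ring, the change from compound 2 being methyl in place of acetyl on an amine nitrogen in a ring at this one place. Going by the values given here, no step between measured compounds speaks to this change. A modest move toward weaker inhibition in this assay is expected, an estimated 1.5-fold higher number from compound 2 to compound 3 (0.18 log units; within the scatter) with wide uncertainty. For compound 3 the estimate is 10000 nM with an expected range from 2500 nM to 40000 nM once measured.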

Compound 3, half-maximal inhibitory concentration: 6590 nM
For compound 3 the middle estimate is 1.5-fold (0.18 log units) above the measured one; low and high end bracket the measured number.
By their numbers in this assay, from the lowest: compounds 1, 2 and 3 (each within the scatter of the next).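

In this assay, methyl in place of acetyl on the amine nitrogen in a ring gives no change at the digits printed from compound 2 to compound 3 (within the scatter). The earlier compounds shown here held this position constant; now the acetyl, with its one hydrogen-bond acceptor, is seen to leave it without a shift beyond the scatter. No measurement shown accounts for this result.

Open, going by these compounds, is whether a benzyl group or a longer chain on this nitrogen would shift the number beyond the scatter. Also open, on these data alone, is whether the same change behaves alike on the core of compound 1.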